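Benzyl swap on the compound 1 core: methoxy to dimethyl

The source may hold more compounds than are shown below. What is called first, only, known or untested is meant among the compounds shown, and "the series" means these compounds.

Measured so far:
- compound 1 `COc1ccccc1CN(C)C(=O)c1c(-c2ccc(F)cc2)c2cccnc2c(=O)n1C` — an assay on IM-9 cells for binding affinity to Substance-P receptor (Homo sapiens); on this read-out lower numbers stand for stronger inhibition and higher numbers for weaker inhibition: 2.5 nM
- compound 2 `Cc1cc2c(-c3ccccc3)c(C(=O)N(C)Cc3cc(C(F)(F)F)cc(C(F)(F)F)c3)n(C)c(=O)c2cc1C` — this assay : 8.4 nM

Compound 1 stands at the lowest of the two numbers; compound 2 sits at the higher one, and the gap between the two is beyond the usual scatter. Going by the values given here, the two compounds differ both in the core and in the benzyl group on the amide nitrogen, so neither difference can be read off on its own, and no single-point step between measured compounds is available.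

Compound 3 `Cc1cc(C)cc(CN(C)C(=O)c2c(-c3ccc(F)cc3)c3cccnc3c(=O)n2C)c1` keeps the core of compound 1 and changes only the benzyl group: 3,5-dimethylphenyl in place of 2-methoxyphenyl on a saturated chain carbon bound to an amide-type nitrogen. The incoming group, like the benzyl group of compound 2, carries two substituents on the ring, but compound 2 sits on a different core, so its value of 8.4 nM gives no clean guide. The expectation is a modest step towards a weaker number, a 2.0-fold higher number from compound 1 to compound 3 (0.30 log units; within the scatter), most likely not beyond the scatter. Compound 3 is therefore estimated at 5 nM, with a range of 1.5 nM to 20 nM.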

Compound 3, half-maximal inhibitory concentration: 5.1 nM
For compound 3 the middle estimate is 1.0-fold (0.01 log units) below the measured one; the measured number falls inside the stated range.
By their numbers in this assay, from the lowest: compound 1; then compounds 3 and 2 (each within the scatter of the next).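

Going by these compounds alone, on the core of compound 1, in this assay, 3,5-dimethylphenyl in place of 2-methoxyphenyl on a saturated chain carbon bound to an amide-type nitrogen gives a 2.0-fold higher number from compound 1 to compound 3 (0.31 log units; beyond the scatter), the first reading of this position with the core held fixed. The position therefore responds to the identity of the benzyl group, although the change is modest: the ring type and heavy-atom count stay the same, the oxygen and its hydrogen-bond acceptor leave, and compound 3 still reads 5.1 nM. No measured information bears on what lies behind this step.

This single step does not separate the loss of the methoxy group from the arrival of the two methyl groups, and an unsubstituted benzyl group on the same core would give the reference needed to tell them apart. Going by these compounds, compound 2 differs from the others in both core and benzyl group, so the effect of trifluoromethyl groups on the benzyl ring on the core of compound 1 remains open, as does that of a pyridine ring in place of the benzene ring.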